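Two sulfonamide analogues and a styryl replacement

The source may report more compounds than this note shows. Statements on the series, on what has been measured and on what is new or still open speak of the compounds shown alone.

Of the compounds shown here, two share a common core and have been tested in a functional assay on HeLa cells (Homo sapiens) for cytotoxicity, read by MTT assay, with a stated time of 72 h; a lower number here means a stronger inhibitor, a higher number a weaker inhibitor. Compound 1, `NS(=O)(=O)c1cc(-c2nnc(CN3CCN(Cc4ccccc4)CC3)o2)c(Cl)cc1SCc1ccccc1`, carries a benzylpiperazinylmethyl group on the five-membered ring and gives 17000 nM in this assay. Compound 2, `CC(C)(O)c1cn(Cc2nnc(-c3cc(S(N)(=O)=O)c(SCc4ccccc4)cc3Cl)o2)nn1`, carries a (4-(1-hydroxy-1-methylethyl)-1H-1,2,3-triazol-1-yl)methyl group at the same position and gives 68000 nM in this assay. On these two numbers compound 2 stands highest, and its gap to compound 1 lies beyond the scatter, so compound 2 is the weaker inhibitor of the pair.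

Compound 3, `NS(=O)(=O)c1cc(-c2nnc(/C=C/c3ccc(Cl)cc3)o2)c(Cl)cc1SCc1ccccc1`, has not yet been measured. It differs from compound 2 in one place: 2-(4-chlorophenyl)ethenyl in place of (4-(1-hydroxy-1-methylethyl)-1H-1,2,3-triazol-1-yl)methyl on an aromatic carbon. Among the measured compounds shown here, no measured pair describes this particular change, so the size of the step is uncertain. Since both measured values are weak, the expected step of a 2.7-fold lower number from compound 2 to compound 3 (0.43 log units; beyond the scatter) is a modest move toward a lower number, with a wide range either way. Compound 3 is therefore estimated at 25000 nM, between 6000 nM and 100000 nM, in this assay.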

Compound 3, half-maximal inhibitory concentration: 40000 nM
Beside the measured number, compound 3's estimate is 1.6-fold (0.20 log units) below it; low and high end bracket the measured number.
By their numbers in this assay, from the lowest: compound 1; then compounds 3 and 2 (each within the scatter of the next).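

In this assay, putting 2-(4-chlorophenyl)ethenyl in place of (4-(1-hydroxy-1-methylethyl)-1H-1,2,3-triazol-1-yl)methyl on this aromatic carbon gives a 1.7-fold lower number from compound 2 to compound 3 (0.23 log units; within the scatter) and so leaves the number inside the usual scatter. On paper the exchange is large: a five-membered aromatic ring with 3 hetero atoms, 1 hydrogen-bond donor and 4 hydrogen-bond acceptors leaves, while a six-membered aromatic ring of carbon only, with 0 hydrogen-bond donors and 0 hydrogen-bond acceptors, enters, yet for this one pair the difference in those counts comes with no readable change in the number. No measurement at hand gives a reason for this outcome.

A single pair cannot show whether this position is insensitive in general or whether only these two groups happen to give similar numbers. From the compounds shown here alone, whether an amine or a carboxylic acid on this same carbon, or a phenyl ring without its chlorine at the end of the ethenyl link, would move the number in this assay beyond the scatter stays open.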